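The source may hold more compounds than are shown below. What is called first, only, known or untested is meant among the compounds shown, and "the series" means these compounds.

In a functional assay on HepG2 cells (Homo sapiens) for cytotoxicity, read by MTT assay, with a stated time of 48 h (a higher number here means a weaker inhibitor, a lower number a stronger inhibitor), compound 3 `CCCCCCOc1ccc2c(NCCN(C)C)ccnc2c1` gives 1370 nM, the lowest of the three numbers measured. Compound 1 `CCCCCCOc1ccc2c(Cl)ccnc2c1` gives 2420 nM, and the step of a 1.8-fold lower number from compound 1 to compound 3 (0.25 log units; within the scatter) is small. Compound 2 `CCOc1ccc2c(NCCCN(C)C)ccnc2c1` gives 5860 nM, a number beyond the scatter from compound 3, but compound 2 differs from compound 3 in two places, so its gap cannot be tied to a single change. Compound 4 `CN(C)CCNc1ccnc2cc(OCc3ccc(F)cc3)ccc12` carries 4-fluorophenyl in place of pentyl on a saturated chain carbon bound to an oxygen on an aromatic ring. Among the measured compounds shown here, no measured step alters this part of the shared core on its own, so nothing here sizes the step; the expectation is therefore a change no larger than the scatter, in either direction, with a wide range. Compound 4 is expected to give 1500 nM, between 500 nM and 5000 nM. This expectation amounts to a 1.1-fold higher number from compound 3 to compound 4 (0.04 log units; within the scatter).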

Compound 4, half-maximal inhibitory concentration: 790 nM
Beside the measured number, compound 4's estimate is 1.9-fold (0.28 log units) above it; the range from low to high includes it.
By their numbers in this assay, from the lowest: compounds 4, 3 and 1 (each within the scatter of the next, the first and the last beyond it); then compound 2.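

The change at this position is a large one in kind, from an open chain to an aromatic ring, yet in this assay it gives a 1.7-fold lower number from compound 3 to compound 4 (0.24 log units; within the scatter). Hexyl and 4-fluorobenzyl therefore cannot be told apart in this cell assay, which no earlier step could show, since none altered this group. No evidence is available to explain this result.

As far as these compounds go, what a plain benzyl group without the fluorine, or an octyl chain, would give at this place remains open. So does whether any group here can move the number beyond the scatter.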